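Side-chain isomers of one flavanone-type core: cytotoxicity notes

The source may report more compounds than this note shows. Statements on the series, on what has been measured and on what is new or still open speak of the compounds shown alone.

Measured so far:
compound 1 `C/C(=C\Cc1c(O)ccc2c1O[C@H](c1ccc(O)cc1)CC2=O)C/C=C/C(C)(C)O` — > 10000 nM
compound 2 `COC(C=C(C)C)C/C(C)=C/Cc1c(O)ccc2c1O[C@H](c1ccc(O)cc1)CC2=O` — > 10000 nM

In a functional assay on HepG2 cells (Homo sapiens) for cytotoxicity, read by MTT assay (on this read-out lower numbers stand for stronger inhibition and higher numbers for weaker inhibition), compound 1 gives > 10000 nM, which is a limit of the assay and not a number. In this assay compound 2 also gives > 10000 nM, again a limit. The step that the two limits leave unreadable from compound 1 to compound 2 therefore cannot be read, and the limit of > 10000 nM in this assay, at which 2 of the 2 values shown sit, is the only mark the two measured compounds leave. Compound 3 `CC1=CCC(O)C(C)(C)C1Cc1c(O)ccc2c1O[C@H](c1ccc(O)cc1)CC2=O` differs from compound 1 by 5-hydroxy-2,6,6-trimethylcyclohex-2-en-1-yl in place of 6-hydroxy-2,6-dimethylhepta-1,4-dien-1-yl on a saturated chain carbon bound to an aromatic carbon; the same atoms are joined differently, an open chain becoming a ring. Going by the values given here, no measured step bears directly on this change, the single recorded step being unreadable. For compound 3 a step that the limit leaves unreadable from compound 1 to compound 3 is expected, because the limit of > 10000 nM in this assay, at which 2 of the 2 values shown sit, is where both measured compounds sit, and nothing in the shown numbers points away from it. Compound 3 is estimated at 20000 nM, between 8000 nM and 60000 nM, most probably reported again only as a limit.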

Compound 3, half-maximal inhibitory concentration: > 10000 nM
Compound 3 was reported as a limit; the forecaster's own chance of this, stated with the estimate: 85%; the middle value is on the limit's open side.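

Going by these compounds alone, compound 3 is again recorded as a limit and not a number, as are compound 1 and compound 2, so no step among them can be read. Left open is how the open chains and the ring compare in this assay, the only mark so far being: the limit of > 10000 nM in this assay, at which 3 of the 3 values shown sit.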